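The compounds below may be only part of what the source reports. "The series", "measured", "known", "first", "only" and "open" are said of these compounds alone.

Measured so far:
compound 1 `C/C=C1/[C@H](O[C@@H]2O[C@H](CO)[C@@H](O)[C@H](O)[C@H]2O)OC=C(C(=O)OC)[C@H]1CC(=O)OCCc1ccc2c(c1)OCCO2`: > 20000 nM
compound 2 `C/C=C1/[C@H](O[C@@H]2O[C@H](COC(C)=O)[C@@H](OC(C)=O)[C@H](OC(C)=O)[C@H]2OC(C)=O)OC=C(C(=O)O)[C@H]1CC(=O)OC`: > 20000 nM

In a functional assay on SK-BR-3 cells (Homo sapiens) for antiproliferative activity, read by MTT assay, with a stated time of 72 h (on this read-out lower numbers stand for stronger inhibition and higher numbers for weaker inhibition), compound 1 gives only a limit, > 20000 nM. Compound 2 likewise shows only a limit in this assay, > 20000 nM. Both measured values sit at the limit of > 20000 nM in this assay, at which 2 of the 2 values shown sit, so compound 1 stands at that limit with nothing to set it apart. Compound 3 `C/C=C1/[C@H](O[C@@H]2O[C@H](CO)[C@@H](O)[C@H](O)[C@H]2O)OC=C(C(=O)OC)[C@H]1CC(=O)OCCc1ccccc1` differs from compound 1 in one place: phenyl in place of 2,3-dihydro-1,4-benzodioxin-6-yl on a saturated chain carbon, two bonds along the chain from an oxygen next to a carbonyl group. Among the compounds with values here, with no measured step to lean on, the change is expected to bring no shift beyond the scatter, most likely leaving the value at the limit. Compound 3 is therefore expected to give 20000 nM in this assay, within 8000 nM to 50000 nM, an estimated step of a number no higher from compound 1 to compound 3 (the limit leaves the size open).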

Compound 3, half-maximal inhibitory concentration: 11000 nM
Beside the measured number, compound 3's estimate is 1.8-fold (0.26 log units) above it; the range from low to high includes it.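

With phenyl in place of 2,3-dihydro-1,4-benzodioxin-6-yl at this saturated chain carbon, this assay gives its first actual number rather than a limit, and the change reads as an at least 1.8-fold lower number from compound 1 to compound 3 (0.25 log units; that floor lies within the scatter). On these data alone, the true size of this step stays open because compound 1 gives only a limit: the limit of > 20000 nM in this assay, at which 2 of the 3 values shown sit. Even so, the simpler phenyl group is enough to give a measurable number at this position. The compounds shown leave open whether a pyridine ring in place of phenyl, or a longer chain carrying the phenyl, would lower the number further.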